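The source may report more compounds than this note shows. Statements on the series, on what has been measured and on what is new or still open speak of the compounds shown alone.

Of the compounds shown here, two have so far been tested in a functional assay on HEK293 cells for agonist activity at Bile acid receptor (Homo sapiens), read by a luciferase reporter; on this read-out higher numbers stand for larger maximal responses and lower numbers for smaller maximal responses. Compound 1 `CN(Cc1ccc(C(=O)O)cc1)c1ccc(OCc2c(-c3c(Cl)cccc3Cl)noc2C2CC2)nc1C(F)(F)F` reaches 60%. Going by the values given here, compound 2 `O=C(O)c1ccc(OCc2ccc(OCc3c(-c4c(Cl)cccc4Cl)noc3C3CC3)nc2C(F)(F)F)cc1` reaches 42%, which is the lower of the two numbers; the single measured step is a number 18 percentage points lower from compound 1 to compound 2 (beyond the scatter). Compound 3 `CC(Oc1ccc(C(=O)O)cc1)c1ccc(OCc2c(-c3c(Cl)cccc3Cl)noc2C2CC2)nc1C(F)(F)F` has not been measured yet. It differs from compound 2 by one small change: methyl in place of hydrogen on a saturated chain carbon bound to an aromatic carbon and an oxygen on an aromatic ring. Among the compounds with values here, the only measured step, the one from compound 1 to compound 2, concerns a different part of the molecule and therefore says nothing direct about adding a methyl at this spot; no measured step bears on the change. With nothing pointing either way, the expected step for compound 3 is one that stays within the scatter, estimated as a number 3 percentage points higher from compound 2 to compound 3 (within the scatter). Compound 3 is accordingly expected to reach 45%, within a range from 25% to 65%.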

Compound 3, largest response reached (reported as efficacy), in percent of the reference or control that the assay uses: 33%
Estimate against measurement, compound 3: 12 percentage points above, within the range that was stated.
By their numbers in this assay, from the lowest: compounds 3 and 2 (each within the scatter of the next); then compound 1.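

In this assay, methyl in place of hydrogen on this saturated chain carbon gives a number 9 percentage points lower from compound 2 to compound 3 (within the scatter), so a single added carbon at this spot produces no change that can be told apart from the scatter. Compared with the amine-linked compound, 1-(4-carboxyphenoxy)ethyl in place of (4-carboxybenzyl)(methyl)amino gives a number 27 percentage points lower from compound 1 to compound 3 (beyond the scatter), a step beyond the scatter and larger than the one seen without the methyl. Nothing measured here explains these numbers.

Going by these compounds, whether an ethyl or a hydroxyl on the same chain carbon would give a step beyond the scatter remains open. Also open, on these data alone, is how the number would respond to a hydrogen in place of the methyl on the nitrogen of compound 1.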